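Stripping the Aryl Substituent: Compound 2 to Compound 3

A few compounds are considered here, and "the series" means these few. Any claim that something is new, unique, unknown or untested is made for them only; others in the source may bear on it.

Compound 1 `CCCCCCCCCCCCCCNC(=O)[C@@H]1CSC(c2ccc(OC)c(OC)c2)N1`: 800 nM
Compound 2 `CCCCCCCCCCCCCCNC(=O)[C@@H]1CSC(c2ccc(NC(C)=O)cc2)N1`: 600 nM

Both compounds were tested in a functional assay on WM164 cells (Homo sapiens) for antiproliferative activity, read by sulforhodamine B assay, with a stated time of 48 h; a lower number here means a stronger inhibitor, a higher number a weaker inhibitor. Compound 2 gives the lowest of the two numbers, yet its nearest neighbour, compound 1, sits only a 1.3-fold lower number from compound 1 to compound 2 (0.12 log units; within the scatter) away, so the two cannot be told apart. Compound 3 `CCCCCCCCCCCCCCNC(=O)[C@@H]1CSC(c2ccccc2)N1` has not been measured. It differs from compound 2 by hydrogen in place of acetamido on an aromatic carbon. Within the data shown here, the one measured step, a 1.3-fold lower number from compound 1 to compound 2 (0.12 log units; within the scatter), exchanged one aryl group for another and stayed within the scatter, so no measurement shows directly what removing the acetamido group does. Because a 1.3-fold lower number from compound 1 to compound 2 (0.12 log units; within the scatter) was small, the number for compound 3 is expected to shift only modestly, by an estimated 1.7-fold higher number from compound 2 to compound 3 (0.22 log units; within the scatter) toward a weaker inhibitor. Compound 3 is estimated at 1000 nM, within a range from 400 nM to 3000 nM.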

Compound 3, half-maximal inhibitory concentration: 600 nM
Estimate against measurement, compound 3: 1.7-fold (0.22 log units) above, within the range that was stated.
By their numbers in this assay, from the lowest: compounds 2, 3 and 1 (each within the scatter of the next).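

Taking the acetamido group off the aromatic ring in this assay leaves no change at the digits printed from compound 2 to compound 3 (within the scatter) and so shows directly that, in this series, this group is not needed to keep the number where it stands. The plain phenyl compound also compares with the dimethoxy compound as a 1.3-fold lower number from compound 1 to compound 3 (0.12 log units; within the scatter) and so the ring without any substituent cannot be told apart from either substituted ring, which means that none of the three aryl groups stands out in this assay. No measurement at hand offers an explanation for this flat result.

On these data alone, what remains open is whether a quite different group in place of that hydrogen, such as an amine or a carboxylic acid, would move the number beyond the scatter. The compounds shown also leave open what a shorter chain on the amide would do, since that chain is the same in all three.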